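From Aminophenyl to Dichlorophenyl on the Carbonyl

This account rests on a few compounds, and the source may have more. Where it says the series, first, only, none or still open, it means among the compounds named here.

Of the compounds shown here, two have been measured so far. Compound 1 `COc1ccc(-c2cc(/C=C/C(=O)c3ccc(N)cc3)[nH]n2)cc1` in a functional assay on HOP-62 cells (Homo sapiens) for cytotoxicity, read by sulforhodamine B assay, with a stated time of 48 h, tested at 1 uM (a lower number here means a stronger effect, a higher number a weaker effect of the compound at the concentration tested), gives 102%. Compound 2 `COc1cc(-c2cc(/C=C/C(=O)c3ccc(N)cc3)[nH]n2)cc(OC)c1OC` gives 86%, the lowest of the two numbers; compound 1 sits higher by an amount beyond the usual scatter, so compound 2 shows the stronger effect of the pair.

Compound 3 `COc1cc(-c2cc(/C=C/C(=O)c3ccc(Cl)c(Cl)c3)[nH]n2)cc(OC)c1OC` has not yet been measured. It differs from compound 2 in a single place: 3,4-dichlorophenyl in place of 4-aminophenyl on a carbonyl carbon. The rest of the shared core, including the trimethoxyphenyl portion of compound 2, is unchanged.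

Among the compounds with values here, no step between two measured compounds that differ in one place is available, so the effect of this exchange has no direct precedent here. On the numbers shown, the step of a number 8 percentage points lower from compound 2 to compound 3 (within the scatter) is expected to be a modest lowering, at the edge of the scatter rather than clearly beyond it. Accordingly compound 3 is estimated to give 78%, with a range from 50% to 105%.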

Compound 3, a percentage reported as activity, at one concentration (the size of the read-out at that concentration, not a potency): 68%
Compound 3: the middle estimate sits 10 percentage points above what was measured; the range from low to high includes it.
By their numbers in this assay, from the lowest: compound 3; then compound 2; then compound 1.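

In this assay, within the data shown here, the two earlier compounds both carried 4-aminophenyl on the carbonyl carbon, so they said nothing about this position; the exchange for 3,4-dichlorophenyl now gives a number 18 percentage points lower from compound 2 to compound 3 (beyond the scatter), the first reading of a single change here. The step shows that the group on this carbonyl carbon can change the read-out, and that the 4-aminophenyl group, with its hydrogen-bond donor and acceptor, is not required for the effect seen in compound 2, since compound 3, whose new group has neither, gives 68%. Nothing available explains why the number falls with this exchange.

From the compounds shown here alone, this one step cannot separate the departure of the amine from the arrival of the two chlorine atoms, so it remains open whether a phenyl ring with a single chlorine, or a plain phenyl ring, would give a similar number. Going by these compounds, it also remains open whether a methoxy group or a carboxylic acid on the phenyl ring at this carbonyl carbon would move the read-out further in either direction, and whether this step would hold on a different core.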